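Swapping the aryl group on the amine nitrogen

The compounds below may be only part of what the source reports. "The series", "measured", "known", "first", "only" and "open" are said of these compounds alone.

Measured compounds in a functional assay on PC-3 cells (Homo sapiens) for antiproliferative activity, read by MTT assay, with a stated time of 48 h; a higher number here means a weaker inhibitor, a lower number a stronger inhibitor:
compound 1, `COc1cc(N/C=C\C(=O)c2cn(-c3ccccc3)nc2-c2ccccc2)cc(OC)c1OC`: 5930 nM
compound 2, `COc1cc(-c2nn(-c3ccccc3)cc2C(=O)/C=C\Nc2ccc(C(F)(F)F)cc2)cc(OC)c1OC`: > 50000 nM

Compound 2 gives no number in this assay; its value is only a limit, > 50000 nM. Compound 2 therefore stands at the limit of > 50000 nM in this assay, at which 1 of the 2 values shown sits. Compound 1 gives a measured value, 5930 nM, and carries the 3,4,5-trimethoxyphenyl on the amine nitrogen. Compound 3, `COc1cc(N/C=C\C(=O)c2cn(-c3ccccc3)nc2-c2cc(OC)c(OC)c(OC)c2)cc(OC)c1OC`, is not yet measured. It differs from compound 2 by 3,4,5-trimethoxyphenyl in place of 4-(trifluoromethyl)phenyl on an amine nitrogen. Among the compounds with values here, no single-point step between the two measured compounds is available, so the expected size of the change rests on compound 1 alone. Because compound 1 holds the same group on the amine nitrogen and gives 5930 nM, the step of an at least 12-fold lower number from compound 2 to compound 3 (1.09 log units; beyond the scatter) is expected to run toward stronger inhibition, well beyond the scatter. Compound 3 is therefore estimated at 4000 nM, within 1000 nM to 20000 nM.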

Compound 3, half-maximal inhibitory concentration: 14100 nM
The estimate for compound 3 lay 3.5-fold (0.55 log units) below the measured number; measured number inside the range.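

In this assay, the amine nitrogen now shows a response to its aryl group: 3,4,5-trimethoxyphenyl in place of 4-(trifluoromethyl)phenyl gives an at least 3.5-fold lower number from compound 2 to compound 3 (0.54 log units; beyond the scatter). That step is a bound and not an exact size, as compound 2 gives only a limit: the limit of > 50000 nM in this assay, at which 1 of the 3 values shown sits. The aromatic carbon that carries phenyl in compound 1 also responds: 3,4,5-trimethoxyphenyl in place of phenyl there gives a 2.4-fold higher number from compound 1 to compound 3 (0.38 log units; beyond the scatter), a modest shift toward weaker inhibition, so this exchange does not strengthen inhibition at that place.

The compounds shown do not settle whether the step on the amine nitrogen follows from gaining 3,4,5-trimethoxyphenyl or from losing 4-(trifluoromethyl)phenyl. A 4-methoxyphenyl or a plain alkyl chain on that nitrogen would help separate the two readings.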